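Ethoxy for ethyl at the shared core: expected antiproliferative read-out

The source may hold more compounds than are shown below. What is called first, only, known or untested is meant among the compounds shown, and "the series" means these compounds.

Compound 3 `CCc1ccc2nc(C(=O)Nc3c(F)cc(-c4cccc(F)c4)cc3F)c(C)c(C(=O)O)c2c1` stands second highest of the three numbers in a functional assay on Hep 3B2 cells (Homo sapiens) for antiproliferative activity, read by MTT assay, with a stated time of 24 h, tested at 100 ug/mL; a lower number here means a weaker effect, a higher number a stronger effect of the compound at the concentration tested: compound 3 gives 64.3%. Within the data shown here, its nearest neighbour is compound 2 `Cc1ccc2nc(C(=O)Nc3c(F)cc(-c4cccc(F)c4)cc3F)c(C)c(C(=O)O)c2c1`, which gives 75.2%; the one single-place step measured so far, a number 10.9 percentage points lower from compound 2 to compound 3 (beyond the scatter), is the gap between them. Furthest away lies compound 1 `CCOc1ccc2nc(C(=O)Nc3c(F)cc(-c4cccc(F)c4)cc3F)c(C)c(O)c2c1`, which gives 33.3%; compound 1 differs from compound 3 in two places, so only its value is known, not a step.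

Compound 4 `CCOc1ccc2nc(C(=O)Nc3c(F)cc(-c4cccc(F)c4)cc3F)c(C)c(C(=O)O)c2c1` differs from compound 3 by ethoxy in place of ethyl on an aromatic carbon. Among the measured compounds shown here, no measured step concerns an ethoxy group; the one step available, a number 10.9 percentage points lower from compound 2 to compound 3 (beyond the scatter), concerns a carbon chain lengthened at the same place and was modest. Compound 1 carries the same ethoxy group as compound 4 but a hydroxyl in place of the carboxylic acid, so its lower number cannot be separated into the two changes. A small step downward, or none beyond the scatter, is therefore expected in this assay, a number 6.3 percentage points lower from compound 3 to compound 4 (within the scatter). Compound 4 is estimated at 58%, within 40% to 76%.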

Compound 4, a percentage reported as inhibition, at one concentration (the size of the read-out at that concentration, not a potency): 65.3%
For compound 4 the middle estimate is 7.3 percentage points below the measured one, and the stated range covers the measured number.
By their numbers in this assay, from the lowest: compound 1; then compounds 3, 4 and 2 (each within the scatter of the next, the first and the last beyond it).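

In this assay, ethoxy in place of ethyl on an aromatic carbon gives a number 1 percentage points higher from compound 3 to compound 4 (within the scatter), and ethoxy in place of methyl at the same carbon gives a number 9.9 percentage points lower from compound 2 to compound 4 (within the scatter), so neither step lies beyond the scatter and this place has so far tolerated all three groups at the concentration tested. With the ethoxy group held constant, carboxy in place of hydroxy gives a number 32 percentage points higher from compound 1 to compound 4 (beyond the scatter), which ties the low number of compound 1 to the hydroxy group and not to the ethoxy group. Nothing measured here gives a reason for either result.

On these data alone, what a longer chain such as propoxy, or an amine, would give at the ethoxy place stays open. As far as these compounds go, at the carboxy place, the outcome with a methyl ester or a primary amide is equally open.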